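A few compounds are considered here, and "the series" means these few. Any claim that something is new, unique, unknown or untested is made for them only; others in the source may bear on it.

Series notes. In an assay on isolated protein for inhibition of Amine oxidase [flavin-containing] B (Homo sapiens), read by fluorescence and Amplex Red, with a stated time of 15 min, tested at 50 uM (a higher number here means more inhibition at the concentration tested (going by the name of the read-out), a lower number less inhibition), compound 1 `C#CCN(CC)Cc1cn(-c2cc(NC(=S)NCC)ncn2)cn1` gives 35.1%, compound 2 `C#CCN(CCCC)Cc1cn(-c2cc(NC(=S)NCC)ncn2)cn1` gives 20.1%, and compound 3 `C#CCN(Cc1cn(-c2cc(NC(=S)NCC)ncn2)cn1)C(C)=O` gives 1.17%. Compound 2 thus stands second highest of the three numbers; the nearer gap is a number 15 percentage points lower from compound 1 to compound 2 (beyond the scatter), the wider one a number 18.9 percentage points lower from compound 2 to compound 3 (beyond the scatter). Compound 4 `C#CCN(Cc1ccccc1)Cc1cn(-c2cc(NC(=S)NCC)ncn2)cn1` is not yet measured; its change from compound 2 is phenyl in place of propyl on a saturated chain carbon bound to an amine nitrogen. The step that bears on it is a number 15 percentage points lower from compound 1 to compound 2 (beyond the scatter), a modest drop as the group on the amine nitrogen grew; the acetyl steps a number 33.9 percentage points lower from compound 1 to compound 3 (beyond the scatter) and a number 18.9 percentage points lower from compound 2 to compound 3 (beyond the scatter) involve a different kind of group and are set aside. A further modest lowering in this assay is expected, a number 4.1 percentage points lower from compound 2 to compound 4 (within the scatter). On the strength of a number 15 percentage points lower from compound 1 to compound 2 (beyond the scatter), compound 4 is expected to give 16%, between 4% and 32%.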

Compound 4, a percentage reported as inhibition, at one concentration (the size of the read-out at that concentration, not a potency): 18.4%
For compound 4 the middle estimate is 2.4 percentage points below the measured one; measured number inside the range.
By their numbers in this assay, from the lowest: compound 3; then compounds 4 and 2 (each within the scatter of the next); then compound 1.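

In this assay, butyl and benzyl on the amine nitrogen cannot be told apart (a number 1.7 percentage points lower from compound 2 to compound 4 (within the scatter)), so a phenyl in place of propyl at this position shows no separate effect. Benzyl also sits modestly under ethyl (a number 16.7 percentage points lower from compound 1 to compound 4 (beyond the scatter)) and modestly over acetyl (a number 17.2 percentage points higher from compound 3 to compound 4 (beyond the scatter)), the same placing as butyl. Nothing at hand accounts for these numbers.

Open, from the compounds shown here alone, is whether a methyl or a phenethyl on the amine nitrogen would follow ethyl or butyl and benzyl in this assay.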